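Swapping a Ring for a Chain on the Amide Nitrogen

The source may report more compounds than this note shows. Statements on the series, on what has been measured and on what is new or still open speak of the compounds shown alone.

Compound 2 `O=C(O)c1cc(-c2cccc(COc3ccc4c(c3)CN(C3CCC3)C4=O)c2)ccc1Cl` belongs to a small set measured in an assay on HEK293 cells for positive allosteric modulation of metabotropic glutamate receptor 2 (Rattus norvegicus), read by thallium flux; on this read-out higher numbers stand for larger maximal responses and lower numbers for smaller maximal responses. Compound 2 gives 90.3%, the higher of two numbers, with compound 1 `O=C(O)c1cc(-c2cccc(COc3ccc4c(c3)CN(CC3CC3)C4=O)c2)ccc1Cl` nearest at 85.7%; the two lie within the usual scatter of each other. Going by the values given here, the only step measured so far, a number 4.6 percentage points higher from compound 1 to compound 2 (within the scatter), is therefore too small to count as a real change.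

Compound 3 `CC(C)CN1Cc2cc(OCc3cccc(-c4ccc(Cl)c(C(=O)O)c4)c3)ccc2C1=O` has not yet been measured. It differs from compound 2 in one place: isobutyl in place of cyclobutyl on an amide-type nitrogen in a ring. This is again an exchange of one four-carbon group for another on the same nitrogen, much like the step from compound 1 to compound 2, which stayed within the scatter. On that basis no step beyond the scatter is expected in this assay for compound 3, in either direction.

The expected result for compound 3 is 88%, with a likely range from 75% to 100%, meaning an expected step of a number 2.3 percentage points lower from compound 2 to compound 3 (within the scatter).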

Compound 3, largest response reached (Emax), in percent of the reference or control that the assay uses: 63.9%
Compound 3: middle estimate off by 24.1 percentage points, on the high side; the whole stated range lies above it.
By their numbers in this assay, from the lowest: compound 3; then compounds 1 and 2 (each within the scatter of the next).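

Replacing cyclobutyl with isobutyl gives a number 26.4 percentage points lower from compound 2 to compound 3 (beyond the scatter) in this assay, so the group on this amide-type nitrogen does matter, even though both groups hold 4 carbons and differ in that isobutyl has no ring. Isopropyl in place of cyclopropyl on the saturated chain carbon bound to that nitrogen gives a number 21.8 percentage points lower from compound 1 to compound 3 (beyond the scatter), so among these three compounds, the two groups containing a ring, cyclobutyl and cyclopropylmethyl, both stand apart from open-chain isobutyl. Nothing measured here explains this difference.

These compounds cannot separate the absence of a ring from the branching of isobutyl, and an unbranched n-butyl chain on the same nitrogen would bear on that question. As far as these compounds go, whether a larger ring, such as cyclopentyl, would match compound 2 also remains open.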